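Carboxylesterase inhibitor series: phenoxymethyl versus phenyl at the terminal ring

This account rests on a few compounds, and the source may have more. Where it says the series, first, only, none or still open, it means among the compounds named here.

Measured compounds:
- compound 1, `O=C(CCc1ccc(COc2ccccc2)cc1)c1ncco1`, 270 nM
- compound 2, `O=C(CCc1ccc(-c2ccccc2)cc1)c1ncc(-c2cccc(-c3nnn[nH]3)n2)o1`, 7000 nM

For the measured compounds named here, of the two numbers so far in an assay on isolated protein for inhibition of liver carboxylesterase 1 (Homo sapiens) (a lower number here means a stronger inhibitor, a higher number a weaker inhibitor), compound 2 gives 7000 nM, the higher of the two, while compound 1 gives 270 nM, a gap well beyond the scatter. Going by the values given here, the two structures differ in more than one place, so no single step between them can be read.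

Compound 3, `O=C(CCc1ccc(COc2ccccc2)cc1)c1ncc(-c2cccc(-c3nnn[nH]3)n2)o1`, takes compound 2 and changes one place: phenoxymethyl in place of phenyl on an aromatic carbon. Compound 3 therefore carries the same phenoxymethyl group as compound 1 on the terminal ring, while keeping the rest of compound 2.

A move towards a lower number is expected for compound 3, since compound 1 shows 270 nM with that same group, although the second difference between compound 1 and compound 2 leaves the size of the step uncertain. The expected step in this assay is a 2.8-fold lower number from compound 2 to compound 3 (0.45 log units; beyond the scatter). Compound 3 is estimated at 2500 nM, within 700 nM to 9000 nM.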

Compound 3, half-maximal inhibitory concentration: 90000 nM
Estimate against measurement, compound 3: 36-fold (1.56 log units) below; the whole stated range lies below it.
By their numbers in this assay, from the lowest: compound 1; then compound 2; then compound 3.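

In this assay, phenoxymethyl in place of phenyl para to a large group is far from neutral on the substituted core, giving a 13-fold higher number from compound 2 to compound 3 (1.11 log units; beyond the scatter). On the core of compound 1, 6-(1H-tetrazol-5-yl)pyridin-2-yl in place of hydrogen on an aromatic carbon gives a 330-fold higher number from compound 1 to compound 3 (2.52 log units; beyond the scatter), so phenoxymethyl goes with the lowest number of the series only in compound 1 and with the highest in compound 3. No measurement at hand bears on why this group behaves so differently in the two compounds.

Open, from the compounds shown here alone, is how phenyl and phenoxymethyl rank on the core without the 6-(1H-tetrazol-5-yl)pyridin-2-yl group. Also open, going by these compounds, is whether a carboxylic acid in place of the tetrazole would give the same ranking of phenyl and phenoxymethyl.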